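Inverting the chain stereocentre of compound 3

A few compounds are considered here, and "the series" means these few. Any claim that something is new, unique, unknown or untested is made for them only; others in the source may bear on it.

Compound 3 `CCCC[C@H](CO)Nc1cc(N)nc2ccccc12` gives in an assay on tissue (PBMC cells) for agonist activity at Toll-like receptor 8 (Homo sapiens), with a stated time of 24 h (on this read-out lower numbers stand for an effect already at smaller amounts and higher numbers for an effect only at larger amounts of compound), only a limit, > 50000 nM. Compound 1 `CCCC[C@H](CN)Nc1nc(N)nc2cccnc12` gives 25000 nM. Compound 2 `CCCC[C@@H](Nc1nc(N)nc2cccnc12)C(=O)NC` also gives only a limit, > 50000 nM. Two of the three values thus sit at the limit of > 50000 nM in this assay, at which 2 of the 3 values shown sit. Within the data shown here, the single measured step, an at least 2.0-fold higher number from compound 1 to compound 2 (0.30 log units; that floor lies within the scatter), exchanges groups on the chain carbon and changes no configuration, so it does not bear on the move to compound 4. Compound 4 `CCCC[C@@H](CO)Nc1cc(N)nc2ccccc12` differs from compound 3 in that (the two compounds have the same atoms and bonds and differ only in configuration as drawn: 1 of 1 stereo elements differ; a stereocentre at a saturated chain carbon is drawn R in compound 3 and S in compound 4). Among the measured compounds shown here, no measured step covers such an inversion, so the expected step of an at least 1.2-fold lower number from compound 3 to compound 4 (0.09 log units; that floor lies within the scatter) rests only on the limit seen for compound 3. Compound 4 is therefore estimated at 40000 nM, within 8000 nM to 50000 nM, with a real chance that again only a limit is reported.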

Compound 4, half-maximal effective concentration: > 50000 nM
Compound 4: a limit, no number; the forecaster's own chance of this, stated with the estimate: 60%; at least 1.2-fold (0.09 log units) between middle value and limit.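

Compound 3 and compound 4 both give only a limit, so no step can be read for this inversion. The compounds shown leave open whether the chain configuration affects the read-out on this core at all.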